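A few compounds are considered here, and "the series" means these few. Any claim that something is new, unique, unknown or untested is made for them only; others in the source may bear on it.

For the measured compounds named here, in a functional assay on RS4-11 cells (Homo sapiens) for inhibition, read by CCK-8 assay, with a stated time of 72 h (on this read-out lower numbers stand for stronger inhibition and higher numbers for weaker inhibition), compound 3 (`CCN(CC)CCCNc1ccc(S(=O)(=O)NC(=O)c2ccc(N3CCN(CC4=C(c5ccc(C(F)(F)F)cc5)CC(C)(C)CC4)CC3)cc2Oc2cnc3[nH]ccc3c2)cc1[N+](=O)[O-]`) gives 3 nM, the lowest of the three numbers so far. Compound 4 (`CC1(C)CCC(CN2CCN(c3ccc(C(=O)NS(=O)(=O)c4ccc(OCC5CCSCC5)c([N+](=O)[O-])c4)c(Oc4cnc5[nH]ccc5c4)c3)CC2)=C(c2ccc(C(F)(F)F)cc2)C1`) differs from it in one place: a group of 8 heavy atoms (6 carbon, 1 oxygen, 1 sulfur; one six-membered non-aromatic ring with 1 hetero atom) in place of a group of 9 heavy atoms (7 carbon, 2 nitrogen; no ring), on an aromatic carbon, ortho to a nitro group. Going by the values given here, no measured step covers this change. The only one, a 1.3-fold higher number from compound 1 to compound 2 (0.11 log units; within the scatter), lies elsewhere in the molecule and stays within the scatter. Compound 1 (`CC1(C)CCC(CN2CCN(c3ccc(C(=O)NS(=O)(=O)c4ccc(NCC5CCOCC5)c([N+](=O)[O-])c4)c(Oc4cnc5[nH]ccc5c4)c3)CC2)=C(c2cccc(C(F)(F)F)c2)C1`) at 63 nM and compound 2 (`CC1(C)CCC(CN2CCN(c3ccc(C(=O)NS(=O)(=O)c4ccc(NCC5CCOCC5)c([N+](=O)[O-])c4)c(Oc4cnc5[nH]ccc5c4)c3)CC2)=C(c2ccc(C(F)(F)F)c(Cl)c2)C1`) at 81 nM also lack the (3-(diethylamino)propyl)amino group and stand well above compound 3, though both differ from it elsewhere too. A clearly higher number is therefore expected in this assay, with an estimated 13-fold higher number from compound 3 to compound 4 (1.12 log units; beyond the scatter). Compound 4 is expected at about 40 nM, within an estimated range of 10 nM to 160 nM.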

Compound 4, half-maximal inhibitory concentration: 15 nM
The estimate for compound 4 lay 2.7-fold (0.43 log units) above the measured number; the measured number falls inside the stated range.
By their numbers in this assay, from the lowest: compound 3; then compound 4; then compounds 1 and 2 (each within the scatter of the next).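

In this assay, for the compounds shown here, the aromatic carbon ortho to a nitro group is the first place where a single change moves the number beyond the scatter: a 5.0-fold higher number from compound 3 to compound 4 (0.70 log units; beyond the scatter), with the ring group of 8 heavy atoms, carrying oxygen and sulfur, replacing (3-(diethylamino)propyl)amino. Going by these compounds alone, the only earlier step, a 1.3-fold higher number from compound 1 to compound 2 (0.11 log units; within the scatter), lay elsewhere in the molecule and within the scatter. On these data alone, whether this step follows the departing chain or the entering ring stays open, as does how a carboxylic acid or a primary amine would compare at this carbon. Nothing available explains the size of this step.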